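Swapping the Distal Ring: From Pyridine to Furan

The source may hold more compounds than are shown below. What is called first, only, known or untested is meant among the compounds shown, and "the series" means these compounds.

Measured so far in an ADME assay on HeLa Rh cells (Homo sapiens) for cytotoxicity, read by microscopy; a higher number here means that more compound is tolerated, a lower number that less compound is tolerated:
- compound 1 `COc1cc(CC(O)c2ccc(-c3ccc(C#N)cc3)cc2)c([N+](=O)[O-])cc1OC`: 4700 nM
- compound 2 `COc1cc(CC(O)c2ccc(-c3ccccc3CO)cc2)c([N+](=O)[O-])cc1OC`: 24000 nM
- compound 3 `COc1cc(CC(O)c2ccc(-c3ccncc3)cc2)c([N+](=O)[O-])cc1OC`: only a limit, > 263000 nM

As far as these compounds go, compound 3 thus stands at the top of the range, sitting at the limit of > 263000 nM in this assay, at which 1 of the 3 values shown sits, so its true number is unknown. Compound 4 `COc1cc(CC(O)c2ccc(-c3ccoc3)cc2)c([N+](=O)[O-])cc1OC` carries furan-3-yl in place of pyridin-4-yl on an aromatic carbon. Going by the values given here, the steps that bear on this are an at least 55-fold higher number from compound 1 to compound 3 (1.74 log units; beyond the scatter) and an at least 10-fold higher number from compound 2 to compound 3 (1.03 log units; beyond the scatter), both reaching the limit; the reverse direction, away from pyridin-4-yl, has so far always meant a lower number. A five-membered ring has not yet been tested, so the size is uncertain. The step is expected to be an at least 8.7-fold lower number from compound 3 to compound 4 (0.94 log units; beyond the scatter). Compound 4 is therefore estimated at 30000 nM, with a likely range from 5000 nM to 263000 nM.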

Compound 4, half-maximal cytotoxic concentration: 5300 nM
Compound 4: the middle estimate sits 5.7-fold (0.75 log units) above what was measured; low and high end bracket the measured number.
By their numbers in this assay, from the lowest: compounds 1 and 4 (each within the scatter of the next); then compound 2. At a limit, above all of these: compound 3.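

Moving from pyridin-4-yl to the five-membered furan-3-yl does not preserve tolerance in this assay: the change gives an at least 49-fold lower number from compound 3 to compound 4 (1.69 log units; beyond the scatter). The value for compound 3 is a limit, so this step is only a minimum: the limit of > 263000 nM in this assay, at which 1 of the 4 values shown sits. Furan-3-yl is not separated from 4-cyanophenyl, with a 1.1-fold higher number from compound 1 to compound 4 (0.05 log units; within the scatter), while replacing 2-(hydroxymethyl)phenyl gives a 4.5-fold lower number from compound 2 to compound 4 (0.66 log units; beyond the scatter).

As far as these compounds go, it remains open whether the ring nitrogen or the ring size separates pyridin-4-yl from furan-3-yl; the two change together. Also open, from the compounds shown here alone, is how a distal ring carrying an amine or a carboxylic acid would behave.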